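Phenoxy to trifluoromethyl on the benzyl end

This account rests on a few compounds, and the source may have more. Where it says the series, first, only, none or still open, it means among the compounds named here.

Compound 1 `CC1=C(C)C(=O)C(CCCCCCCCCCn2cc(C[C@H](O)COCCOC[C@@H](O)Cc3ccc(-c4ccccc4)cc3)nn2)=C(C)C1=O`: 350 nM
Compound 2 `O[C@H](COCCOC[C@@H](O)Cc1cn(Cc2ccc(Oc3ccccc3)cc2)nn1)Cc1ccc(-c2ccccc2)cc1`: 4500 nM

Both values come from a functional assay on SGC-7901 cells (Homo sapiens) for inhibition, read by MTT assay, with a stated time of 72 h; on this read-out lower numbers stand for stronger inhibition of growth and higher numbers for weaker inhibition of growth. Compound 2 has the higher number of the two, and the gap to compound 1 at 350 nM lies beyond the scatter. Compound 3 `O[C@H](COCCOC[C@@H](O)Cc1cn(Cc2ccc(C(F)(F)F)cc2)nn1)Cc1ccc(-c2ccccc2)cc1` carries trifluoromethyl in place of phenoxy on an aromatic carbon, para to a large group: trifluoromethyl in place of phenoxy on an aromatic carbon. Going by the values given here, no measured pair isolates this change, so the expectation is loose. The estimated change is a 1.1-fold higher number from compound 2 to compound 3 (0.05 log units; within the scatter), which would be no step beyond the scatter in this assay. For compound 3 the estimated value is 5000 nM, with an expected range of 1800 nM to 15000 nM.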

Compound 3, concentration for 50% growth inhibition: 8700 nM
Compound 3: the middle estimate sits 1.7-fold (0.24 log units) below what was measured; measured number inside the range.
By their numbers in this assay, from the lowest: compound 1; then compounds 2 and 3 (each within the scatter of the next).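

In this assay, trifluoromethyl in place of phenoxy on the aromatic carbon, para to a large group, gives a 1.9-fold higher number from compound 2 to compound 3 (0.29 log units; within the scatter). The aromatic ring of phenoxy is therefore not needed at this position to keep growth inhibition at the level of compound 2. Nothing on hand explains the result. Going by these compounds, two groups at one position define no trend, so how an amine, a carboxylic acid or a plain hydrogen here would read remains open. On these data alone, whether the same swap holds on other parts of the shared core also remains open.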